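Thiophene-substituted pyrrolopyrimidine nucleosides in a cytotoxicity screen

This account rests on a few compounds, and the source may have more. Where it says the series, first, only, none or still open, it means among the compounds named here.

Four nucleosides built on a shared core are compared in an ADME assay on MRC5 cells (Homo sapiens), read by MTT assay, with a stated time of 72 h; on this read-out higher numbers stand for weaker inhibition and lower numbers for stronger inhibition. Compound 1 `Cc1ncnc2c1c(-c1cccs1)cn2[C@@H]1O[C@H](CO)[C@@H](O)[C@H]1O` carries a thiophen-2-yl group and a methyl on the six-membered ring. In this assay compound 1 gives only the limit > 100000 nM. Compound 2 `CNc1ncnc2c1c(-c1cccs1)cn2[C@@H]1O[C@H](CO)[C@@H](O)[C@H]1O` has a methylamino in place of that methyl. For compound 2 this assay again reports only the limit > 100000 nM. Compound 3 `CNc1ncnc2c1c(-c1ccsc1)cn2[C@@H]1O[C@H](CO)[C@@H](O)[C@H]1O` differs from compound 2 by the change (thiophen-3-yl in place of thiophen-2-yl on an aromatic carbon). Compound 3 likewise shows only the limit > 100000 nM. The step that the two limits leave unreadable from compound 2 to compound 1 and the step that the two limits leave unreadable from compound 2 to compound 3 therefore cannot be sized, and the shared footing of these values is the limit of > 100000 nM in this assay, at which 3 of the 3 values shown sit.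

Compound 4 `Cc1ncnc2c1c(-c1ccsc1)cn2[C@@H]1O[C@H](CO)[C@@H](O)[C@H]1O` has not yet been measured in this assay. It differs from compound 3 by methyl in place of methylamino on an aromatic carbon, which is the same change as methyl in place of methylamino on an aromatic carbon, made from compound 2 to compound 1. That earlier change left the read-out at the limit, so for compound 4 the expected step is a step that the limit leaves unreadable from compound 3 to compound 4 and the expected value is estimated at 150000 nM, resting on the limit seen for compound 1 > 100000 nM.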

Compound 4, half-maximal inhibitory concentration: > 100000 nM
Compound 4 ended at the assay's limit; the forecaster's own chance of this, stated with the estimate: 85%; the middle value is on the limit's open side.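

In this assay compound 4 gives only a limit, > 100000 nM. Neither the step from compound 3 to compound 4 nor the step from compound 1 to compound 4 can therefore be read: the limit of > 100000 nM in this assay, at which 4 of the 4 values shown sit. The compounds shown leave open whether either change alters the read-out, as none has a value that is not a limit.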